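The compounds below may be only part of what the source reports. "The series", "measured", "known", "first", "only" and "open" are said of these compounds alone.

Compound 2 `O=C(NC(=S)Nc1ccccc1)c1ccccc1` gives 1290 nM in an assay for inhibition of epoxide hydrolase 1 (Homo sapiens), read by fluorescence, using microsomes (a higher number here means a weaker inhibitor, a lower number a stronger inhibitor), the lower of the two numbers recorded, though compound 1 `CC(=O)NC(=S)Nc1ccc(Br)cc1` with 1640 nM sits within the usual scatter of it. Compound 3 `CC(=O)NC(=S)Nc1ccccc1` has not been measured. It differs from compound 2 by methyl in place of phenyl on a carbonyl carbon. No step of this kind has been measured among these compounds, so its size can only be expected: a modest rise in the number, toward weaker inhibition, is expected, a 1.7-fold higher number from compound 2 to compound 3 (0.23 log units; within the scatter). Compound 3 is therefore estimated at 2200 nM, with a range from 900 nM to 5500 nM.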

Compound 3, half-maximal inhibitory concentration: 2350 nM
For compound 3 the middle estimate is 1.1-fold (0.03 log units) below the measured one; measured number inside the range.
By their numbers in this assay, from the lowest: compounds 2, 1 and 3 (each within the scatter of the next).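

In this assay, methyl in place of phenyl on a carbonyl carbon gives (a 1.8-fold higher number from compound 2 to compound 3 (0.26 log units; within the scatter)), so at this position the six-membered aromatic ring can be exchanged for a single carbon without a step beyond the scatter. Hydrogen in place of bromo on an aromatic carbon likewise gives only (a 1.4-fold higher number from compound 1 to compound 3 (0.16 log units; within the scatter)), so neither place yet shows a clear effect. Nothing measured here bears on the reason for either step. On these data alone, it remains open whether a longer chain or an amine on that carbonyl carbon would move the number beyond the scatter. The same holds for methoxy or a carboxylic acid on that aromatic carbon.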